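Swapping a carboxy end for an ethoxycarbonyl chain end

A few compounds are considered here, and "the series" means these few. Any claim that something is new, unique, unknown or untested is made for them only; others in the source may bear on it.

compound 1 `COC(=O)Cn1c2ccc([N+](=O)[O-])cc2c(=O)n1Cc1ccccc1`: 129000 nM
compound 2 `O=C(O)CCn1c2ccc([N+](=O)[O-])cc2c(=O)n1Cc1ccccc1`: > 256000 nM (a limit, not a number)

Both compounds were tested in an ADME assay on L929 cells (Mus musculus) for cytotoxicity, read by resazurin assay, with a stated time of 48 h; on this read-out higher numbers stand for lower toxicity in this test and lower numbers for higher toxicity in this test. In this test compound 1 gives 129000 nM. Compound 2 gives > 256000 nM, which is a limit of the assay and not a number. Its true position is therefore not known.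

The next compound is compound 3 `CCOC(=O)CCCn1c2ccc([N+](=O)[O-])cc2c(=O)n1Cc1ccccc1`, and the change from compound 2 is (ethoxycarbonyl)methyl in place of carboxy on a saturated chain carbon, two bonds along the chain from an aromatic nitrogen. In words, this is (ethoxycarbonyl)methyl in place of carboxy on a saturated chain carbon, two bonds along the chain from an aromatic nitrogen.

For the measured compounds named here, the one measured step that bears on this is an at least 1.9-fold higher number from compound 1 to compound 2 (0.29 log units; that floor lies within the scatter). In that step, carboxymethyl took the place of methoxycarbonyl. The new change runs roughly the other way, since the carboxy group leaves, so compound 1 at 129000 nM is the closest guide. A modest move towards a lower number is expected, though it may not clear the scatter. The expected size, read against a limit, is an at least 1.9-fold lower number from compound 2 to compound 3 (0.29 log units; that floor lies within the scatter). For compound 3 the estimated value is 130000 nM, with an expected range from 55000 nM to 256000 nM.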

Compound 3, concentration lethal to 50% of the cells: 78100 nM
Beside the measured number, compound 3's estimate is 1.7-fold (0.22 log units) above it, and the stated range covers the measured number.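

Compound 2 gives > 256000 nM in this assay, which is a limit of the assay and not a number: the limit of > 256000 nM in this assay, at which 1 of the 3 values shown sits.

Even so, replacing the carboxy with (ethoxycarbonyl)methyl now gives a change that can be read, an at least 3.2-fold lower number from compound 2 to compound 3 (0.51 log units; beyond the scatter), whereas the earlier step, an at least 1.9-fold higher number from compound 1 to compound 2 (0.29 log units; that floor lies within the scatter), did not clear the scatter. This is the first sign in the compounds shown that a chain ending in a free carboxy and a chain ending in an ester can differ in this test. The two esters cannot be told apart, however, since the step of a 1.7-fold lower number from compound 1 to compound 3 (0.22 log units; within the scatter) puts 2-(ethoxycarbonyl)ethyl and methoxycarbonyl on the chain carbon bound to the aromatic nitrogen within the scatter of each other.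

The compounds shown leave open how much of the change from compound 2 to compound 3 belongs to the loss of the carboxy and how much to the longer chain and ethyl ester, as both differ together. Also open, on these data alone, is where a chain ending in an amine or an amide would fall in this assay.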